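Adding propanoyl to the free amine of compound 3

The compounds below may be only part of what the source reports. "The series", "measured", "known", "first", "only" and "open" are said of these compounds alone.

In a toxicity assay on Huh-7.5 cells (Homo sapiens) for inhibition, read by MTT assay, with a stated time of 96 h (on this read-out lower numbers stand for higher toxicity in this test and higher numbers for lower toxicity in this test), compound 3 `CC(C)Oc1ccc(C(=O)Nc2ccc(N(C)C)cc2)cc1N` gives 72100 nM. That value lies within the usual scatter of compound 2 `CCC(=O)Nc1cc(C(=O)Nc2ccc(OC)cc2)ccc1OC(C)C` at 113000 nM, and far from compound 1 `CC(C)Oc1ccc(C(=O)Nc2ccc(N(C)C)cc2)cc1NC(=O)C(C)Br` at 7900 nM.

Compound 4 `CCC(=O)Nc1cc(C(=O)Nc2ccc(N(C)C)cc2)ccc1OC(C)C` carries propanoyl in place of hydrogen on a nitrogen on an aromatic ring. For the measured compounds named here, the only measured step at this nitrogen is a 9.1-fold higher number from compound 1 to compound 3 (0.96 log units; beyond the scatter), a modest step beyond the scatter that removes (1-bromoethyl)carbonyl. It does not transfer directly, since propanoyl is a different group. Compound 2 is closer on this point, as it carries propanoylamino and gives 113000 nM, though it also differs from compound 4 elsewhere. No step beyond the scatter is therefore expected in this assay. The estimate is a 1.1-fold higher number from compound 3 to compound 4 (0.05 log units; within the scatter). Compound 4 is expected at 80000 nM, with an estimated range from 35000 nM to 180000 nM.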

Compound 4, half-maximal cytotoxic concentration: 80600 nM
Compound 4: middle estimate off by 1.0-fold (0.00 log units), on the low side; the range from low to high includes it.
By their numbers in this assay, from the lowest: compound 1; then compounds 3, 4 and 2 (each within the scatter of the next).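

In this assay propanoyl in place of hydrogen on the nitrogen gives a 1.1-fold higher number from compound 3 to compound 4 (0.05 log units; within the scatter) and so shows that an amide at this position does not by itself bring the number near that of compound 1. Compound 1 and compound 4 differ in one place. Hydrogen in place of bromo on the saturated chain carbon gives a 10-fold higher number from compound 1 to compound 4 (1.01 log units; beyond the scatter) with the rest of the structure unchanged. Dimethylamino in place of methoxy on an aromatic carbon gives a 1.4-fold lower number from compound 2 to compound 4 (0.15 log units; within the scatter) and so also stays within the scatter.

On these data alone, whether a chloro atom on that chain carbon, or a longer chain in place of propanoyl, would go with a number like that of compound 1 or that of compound 4 remains open. Nothing given here explains why the number changes with the bromo atom.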